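The source may report more compounds than this note shows. Statements on the series, on what has been measured and on what is new or still open speak of the compounds shown alone.

In a functional assay on HT-29 cells (Homo sapiens) for cytotoxicity, read by MTT assay, with a stated time of 72 h (on this read-out lower numbers stand for stronger inhibition and higher numbers for weaker inhibition), compound 1 (`COC(=O)c1sc2nc(C)ccc2c1Nc1cc(OC)c(OC)c(OC)c1`) gives 0.35 nM and compound 2 (`COC(=O)c1sc2ncccc2c1Nc1cc(OC)c(OC)c(OC)c1`) gives 542 nM, so compound 2 holds the higher, weaker number of the two. Compound 3 (`CCOC(=O)c1sc2ncccc2c1Nc1cc(OC)c(OC)c(OC)c1`) has not yet been measured. It departs from compound 2 by methyl in place of hydrogen on a saturated chain carbon bound to an oxygen next to a carbonyl group, turning methoxycarbonyl into ethoxycarbonyl.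

For the measured compounds named here, only one measured step bears on this, and only indirectly: a 1500-fold higher number from compound 1 to compound 2 (3.19 log units; beyond the scatter), a large change for hydrogen in place of methyl on an aromatic carbon. Going by the values given here, that step lies at a different place, and no measured pair varies the methoxycarbonyl group. It shows only that a single methyl can matter greatly in this series. No step beyond the scatter is therefore expected in this assay, and neither direction is favoured. The range stays wide because a 1500-fold higher number from compound 1 to compound 2 (3.19 log units; beyond the scatter) is so large.

The estimate amounts to an expected 1.1-fold lower number from compound 2 to compound 3 (0.04 log units; within the scatter). Compound 3 is expected at 500 nM, with an estimated range of 150 nM to 1700 nM.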

Compound 3, half-maximal inhibitory concentration: 2260 nM
Compound 3: the middle estimate sits 4.5-fold (0.66 log units) below what was measured; the measured number lies above the stated range.
By their numbers in this assay, from the lowest: compound 1; then compound 2; then compound 3.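

In this assay the alkyl end of the ester is now shown to respond to change: turning methoxycarbonyl into ethoxycarbonyl gives a 4.2-fold higher number from compound 2 to compound 3 (0.62 log units; beyond the scatter), so one added methyl on a saturated chain carbon bound to an oxygen next to a carbonyl group is not neutral here. Set against a 1500-fold higher number from compound 1 to compound 2 (3.19 log units; beyond the scatter), which concerns a methyl on an aromatic carbon, the two steps show that the place of a methyl decides the direction: losing the aromatic methyl raises the number, gaining this chain methyl also raises it, and the chain step is much the smaller of the two. No supporting measurement bears on why the number moves at either place.

The compounds shown leave open whether a longer chain such as propyl in place of ethyl continues the rise, and whether a carboxylic acid or an amide in place of the methoxycarbonyl group keeps any activity in this assay. They also leave open whether the step from methoxycarbonyl to ethoxycarbonyl has the same size on the core of compound 1, which carries the aromatic methyl.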